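From chloro to amino on an aromatic carbon

The source may hold more compounds than are shown below. What is called first, only, known or untested is meant among the compounds shown, and "the series" means these compounds.

Of the compounds shown here, three have been measured in a physicochemical assay for acid dissociation. Compound 1 (`Cc1ccc(S(=O)(=O)Nc2ccc(Cl)cc2)cc1`) gives 9.02. Compound 2 (`O=S(=O)(Nc1ccc(Cl)cc1)c1ccc(Cl)cc1`) gives 8.3, and compound 3 (`O=S(=O)(Nc1ccc(Cl)cc1)c1ccc(Br)cc1`) gives 8.24. Compound 2 thus sits level with compound 3 within the scatter, and clearly under compound 1.

Compound 4 (`Nc1ccc(NS(=O)(=O)c2ccc(Cl)cc2)cc1`) departs from compound 2 in one place: amino in place of chloro on an aromatic carbon. Among the compounds with values here, the chloro that leaves is the one shared by all three measured compounds, so no measured step touches that place, and none brings in an amino group. Within the data shown here, the only guides are exchanges at the other substituent. Chloro in place of methyl gave a number 0.72 log units lower from compound 1 to compound 2 (beyond the scatter), bromo in place of methyl gave a number 0.78 log units lower from compound 1 to compound 3 (beyond the scatter), and bromo in place of chloro gave a number 0.06 log units lower from compound 2 to compound 3 (within the scatter). Among these groups only the methyl of compound 1 is not a halogen, and compound 1 carries the highest number, 9.02. Amino is not a halogen either, so a rise at least as large as those modest steps is expected, with wide uncertainty. The expected change is a number 1.40 log units higher from compound 2 to compound 4 (beyond the scatter). For compound 4 the estimated value is 9.7, within an expected range of 9 to 10.4.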

Compound 4, acid dissociation constant: 9.76
Beside the measured number, compound 4's estimate is 0.06 log units below it; the measured number falls inside the stated range.
By their numbers in this assay, from the lowest: compounds 3 and 2 (each within the scatter of the next); then compound 1; then compound 4.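

In this assay, the place that held chloro throughout compounds 1, 2 and 3 proves able to move the number, since amino in place of chloro gives a number 1.46 log units higher from compound 2 to compound 4 (beyond the scatter). This is the first change shown at this place, on an aromatic carbon of a six-membered aromatic ring of carbon only and para to a large group, and it is larger in size than the exchanges at the other substituent, such as a number 0.72 log units lower from compound 1 to compound 2 (beyond the scatter) and a number 0.78 log units lower from compound 1 to compound 3 (beyond the scatter). The exchange swaps a chlorine with no hydrogen-bond donor or acceptor for a nitrogen with one of each, but nothing at hand says what lies behind the size of this step.

The compounds shown leave open whether a methoxy or a dimethylamino group at this place would move the number as far as amino does, and whether a nitrile or a carboxylic acid there would take it the other way. They also leave open whether amino at the other substituent would give a step of similar size, or whether the same exchange would hold with methyl at the other substituent.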